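A few compounds are considered here, and "the series" means these few. Any claim that something is new, unique, unknown or untested is made for them only; others in the source may bear on it.

Within the data shown here, in a functional assay on CHO-K1 cells for antagonist activity at transient receptor potential cation channel subfamily V member 1 (Homo sapiens), read by FLIPR (on this read-out higher numbers stand for weaker inhibition and lower numbers for stronger inhibition), compound 1 `CC(C(=O)NCc1ccc(C(F)(F)F)nc1N(C)c1ccccc1)c1ccc(NS(C)(=O)=O)c(F)c1` gives 0.9 nM, and compound 2 `CC(C(=O)NCc1ccc(C(F)(F)F)nc1N1CCC(C(F)(F)F)CC1)c1ccc(NS(C)(=O)=O)c(F)c1` gives 0.6 nM; compound 2 thus shows the lowest of the two numbers, though its nearest neighbour lies within the scatter, and the only measured step, a 1.5-fold lower number from compound 1 to compound 2 (0.18 log units; within the scatter), alters the same position of the shared core. Compound 3 `CC(C(=O)NCc1ccc(C(F)(F)F)nc1N1CCN(C2CCCCC2)CC1)c1ccc(NS(C)(=O)=O)c(F)c1` carries 4-cyclohexylpiperazin-1-yl in place of 4-(trifluoromethyl)piperidin-1-yl on an aromatic carbon. That earlier step bears on this one, but the entering group is larger, so a modest loss is expected. Compound 3 is estimated to show a 2.2-fold higher number from compound 2 to compound 3 (0.34 log units; beyond the scatter). In this assay compound 3 is expected at 1.3 nM, within 0.35 nM to 5 nM.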

Compound 3, inhibition constant: 21.6 nM
Estimate against measurement, compound 3: 17-fold (1.22 log units) below, and the stated range ends below it.
By their numbers in this assay, from the lowest: compounds 2 and 1 (each within the scatter of the next); then compound 3.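

In this assay the position next to the ring nitrogen proved sensitive to what it carries: 4-cyclohexylpiperazin-1-yl brought a large loss against 4-(trifluoromethyl)piperidin-1-yl (a 36-fold higher number from compound 2 to compound 3 (1.56 log units; beyond the scatter)) and against methyl(phenyl)amino (a 24-fold higher number from compound 1 to compound 3 (1.38 log units; beyond the scatter)). The step between those two earlier groups had stayed within the scatter, so tolerance here does not extend to every large amine. Nothing available accounts for the loss. On these data alone, whether it follows the second ring nitrogen or the cyclohexyl group stays open, and 4-cyclohexylpiperidin-1-yl and 4-methylpiperazin-1-yl would separate the two.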